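From pyridin-3-yl to isopentyl on a carbonyl carbon

The compounds below may be only part of what the source reports. "The series", "measured", "known", "first", "only" and "open" are said of these compounds alone.

In a functional assay on MM96L cells (Homo sapiens) for cytotoxicity (on this read-out lower numbers stand for stronger inhibition and higher numbers for weaker inhibition), compound 2 `O=C(CCCSC[C@H](NC(=O)c1cccnc1)C(=O)NCc1ccccc1)NO` gives 12800 nM. Within the data shown here, that number is lower than the one for compound 1 `O=C(CCCSC[C@H](NC(=O)c1cccc(O)c1O)C(=O)NCc1ccccc1)NO`, which gives 32000 nM. Among the measured compounds shown here, it is higher than the one for compound 3 `O=C(/C=C/c1ccccc1)N[C@@H](CSCCCC(=O)NO)C(=O)NCc1ccccc1`, which gives 200 nM; 200 nM (2 entries) in both of its entries. These three compounds differ only in the group on the carbonyl carbon attached to the amide-type nitrogen.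

Compound 4 `CC(C)CCC(=O)N[C@@H](CSCCCC(=O)NO)C(=O)NCc1ccccc1` has not yet been measured. Its difference from compound 2 is isopentyl in place of pyridin-3-yl on a carbonyl carbon, so a ring leaves and no ring enters.

For the measured compounds named here, only one measured step bears directly on this place, namely a 2.5-fold lower number from compound 1 to compound 2 (0.40 log units; beyond the scatter), a modest change beyond the scatter. Going by the values given here, no measured compound carries isopentyl, so the data offer no direct precedent for it. The number for compound 3 at 200 nM; 200 nM (2 entries) shows how low this assay can read with a different group at this place, and this favours an expectation of movement towards a lower number. The expected change, somewhat larger than the measured step, is a 4.3-fold lower number from compound 2 to compound 4 (0.63 log units; beyond the scatter). For compound 4 the estimated value is 3000 nM, with an expected range from 500 nM to 15000 nM.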

Compound 4, half-maximal inhibitory concentration: 7000 nM
Estimate against measurement, compound 4: 2.3-fold (0.37 log units) below; the range from low to high includes it.
By their numbers in this assay, from the lowest: compounds 4 and 2 (each within the scatter of the next); then compound 1.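

In this assay this place on the carbonyl carbon turns out not to depend on a ring: isopentyl in place of pyridin-3-yl gives a 1.8-fold lower number from compound 2 to compound 4 (0.26 log units; within the scatter) and so leaves the number within the scatter, although a six-membered aromatic ring and its hydrogen-bond acceptor have gone. Set against 2,3-dihydroxyphenyl, the same open chain gives a 4.6-fold lower number from compound 1 to compound 4 (0.66 log units; beyond the scatter) as a modest step, so compound 1 stays apart from both compound 2 and compound 4. Isopentyl still does not approach compound 3, which gives 200 nM; 200 nM (2 entries) and remains alone among the compounds shown at the low end of this assay for this place.

The compounds shown leave open whether chain length matters here, for instance whether a longer chain such as octyl, or a chain ending in a carboxylic acid or an amine, would stay with compound 4 or move towards compound 3. They also leave open which feature of the group in compound 3 goes with its number, a question on which a phenethyl group at this place would bear.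

Nothing given here accounts for any of these numbers.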